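The source may report more compounds than this note shows. Statements on the series, on what has been measured and on what is new or still open speak of the compounds shown alone.

The compounds measured so far:
compound 1, `CCOC(=O)c1sc(NC(=O)Cn2cc(-c3cccs3)nn2)nc1C`: 20 nM
compound 2, `CCOC(=O)c1sc(NC(=O)Cn2cc(-c3ccc(F)cc3)nn2)nc1C`: 660 nM
compound 3, `N#Cc1ccc(-c2cn(CC(=O)Nc3nc4ccccc4s3)nn2)cc1`: > 30000 nM

In a functional assay on BMDM cells (Mus musculus, strain C57BL/6) for inhibition, with a stated time of 2 days (on this read-out higher numbers stand for weaker inhibition and lower numbers for stronger inhibition), compound 1 gives 20 nM and compound 2 gives 660 nM. Within the data shown here, the single measured step in this set is a 33-fold higher number from compound 1 to compound 2 (1.52 log units; beyond the scatter), an exchange of thiophen-2-yl for 4-fluorophenyl. Compound 3 is reported only at the limit of > 30000 nM in this assay, at which 1 of the 3 values shown sits; that is a limit of the assay, not a number. Among the two numbers, compound 2 stands highest, and its nearest neighbour is compound 1, lower by the step just named.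

Compound 4, `Cc1csc(NC(=O)Cn2cc(-c3ccc(F)cc3)nn2)n1`, is not yet measured. It differs from compound 2 in one place: hydrogen in place of ethoxycarbonyl on an aromatic carbon. Among the measured compounds shown here, no measured step touches this change. The step from compound 1 to compound 2 alters another part of the molecule, and compound 3 differs from compound 2 in its core as well as in its aryl group, so its limit cannot be read as a single step against compound 2. The expectation for compound 4 therefore rests on thin ground, and a wide range is appropriate. Compound 4 is estimated at 3000 nM, between 500 nM and 20000 nM. This estimate amounts to a 4.5-fold higher number from compound 2 to compound 4 (0.66 log units; beyond the scatter), a step expected toward weaker inhibition, though a result within the scatter of compound 2 is not excluded.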

Compound 4, half-maximal inhibitory concentration: 250 nM
The estimate for compound 4 lay 12-fold (1.08 log units) above the measured number; measured number outside the range, below it.
By their numbers in this assay, from the lowest: compound 1; then compound 4; then compound 2. At a limit, above all of these: compound 3.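

In this assay, the ethoxycarbonyl group on the aromatic carbon next to the ring sulfur proves dispensable for inhibition when the aryl group is 4-fluorophenyl: hydrogen in its place gives a 2.6-fold lower number from compound 2 to compound 4 (0.42 log units; beyond the scatter) and the compound does not lose activity. Among these compounds, this is the first measured reading at this position, since the only earlier step, a 33-fold higher number from compound 1 to compound 2 (1.52 log units; beyond the scatter), concerned the aryl group, and it shows that 5 heavy atoms and 2 hydrogen-bond acceptors can leave this carbon with a modest gain in inhibition. The change at this carbon is also smaller in size than the aryl exchange, so among the compounds with a number the aryl group moves the read-out more than this position does.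

As far as these compounds go, whether hydrogen in place of ethoxycarbonyl has the same outcome with thiophen-2-yl as the aryl group stays open, as does where a carboxylic acid, a primary amide or a methyl ester on this carbon would fall relative to compound 2 and compound 4. Nothing among the measurements shown gives a cause for the step at this position.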